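The compounds below may be only part of what the source reports. "The series", "measured", "known", "first", "only" and "open" are said of these compounds alone.

Of the compounds shown here, two carrying the same core have been measured in a functional assay on MCF7 cells (Homo sapiens) for inhibition, read by MTT assay, with a stated time of 72 h; on this read-out higher numbers stand for weaker inhibition and lower numbers for stronger inhibition. Compound 1 `CC(C)c1ccc(-c2nc(SCc3cn(CC(=O)NC(=O)Nc4ccccn4)nn3)nc(Nc3cccc(Cl)c3)c2C#N)cc1` gives 18000 nM in this assay. Compound 2 `COc1cc(-c2nc(SCc3cn(CC(=O)NC(=O)Nc4ccccn4)nn3)nc(Nc3ccc(Cl)cc3)c2C#N)cc(OC)c1OC` gives 45100 nM in this assay, which is the higher of the two numbers, and the gap to compound 1 lies beyond the scatter of repeated measurements. Compound 1 and compound 2 differ in more than one place, so the two values alone do not tell which part of the difference carries the gap.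

Compound 3 `COc1cc(-c2nc(SCc3cn(CC(=O)NC(=O)Nc4ccccn4)nn3)nc(Nc3cccc(Cl)c3)c2C#N)cc(OC)c1OC` has not yet been measured. It is reached from compound 2 by a single change, (3-chlorophenyl in place of 4-chlorophenyl on a nitrogen on an aromatic ring). Compound 3 thereby shares its 3-chlorophenyl with compound 1, whose value 18000 nM sits lower than that of compound 2, but compound 1 also carries a different group elsewhere on the core, so this comparison gives only a loose hint. In this assay compound 3 is expected to land at 30000 nM, with a range from 12000 nM to 75000 nM. The expected step of a 1.5-fold lower number from compound 2 to compound 3 (0.18 log units; within the scatter) is estimated to be a small move toward lower numbers, not clearly beyond the scatter.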

Compound 3, half-maximal inhibitory concentration: 24000 nM
Compound 3: middle estimate off by 1.3-fold (0.10 log units), on the high side; low and high end bracket the measured number.
By their numbers in this assay, from the lowest: compounds 1, 3 and 2 (each within the scatter of the next, the first and the last beyond it).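

In this assay, among these compounds, the exchange of 4-chlorophenyl for 3-chlorophenyl on the nitrogen gives the first reading of a single change at this position: a 1.9-fold lower number from compound 2 to compound 3 (0.27 log units; within the scatter). The step does not separate the two chlorophenyl groups on this core, at least when 3,4,5-trimethoxyphenyl is present. With 3-chlorophenyl held fixed, the exchange of 4-isopropylphenyl for 3,4,5-trimethoxyphenyl on the aromatic carbon gives a 1.3-fold higher number from compound 1 to compound 3 (0.12 log units; within the scatter), so neither single change, read alone, has an effect that clears the scatter, and no supporting measurement is available to account for either step.

Only chlorophenyl groups appear on this nitrogen in the compounds shown, so it remains open how an unsubstituted phenyl, a 3-methoxyphenyl or a 3-aminophenyl would read there. Going by these compounds, it is also open whether 4-chlorophenyl and 3-chlorophenyl would stay this close with 4-isopropylphenyl on the core, and whether a carboxylic acid or an amine on the aromatic ring at the other site would shift the number beyond the scatter.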